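Methoxy in place of phenoxy: cytotoxicity on Raji cells

The source may report more compounds than this note shows. Statements on the series, on what has been measured and on what is new or still open speak of the compounds shown alone.

Compound 1 `CCOC(=O)CCCCCOc1cccc(CN(C(=O)c2ccccc2)C(C)C)c1`: in an ADME assay on Raji cells (Homo sapiens) for cytotoxicity, read by CellTiter-Glo and resazurin assay, with a stated time of 72 h (on this read-out lower numbers stand for an effect already at smaller amounts and higher numbers for an effect only at larger amounts of compound), compound 1 gives > 26000 nM.
Compound 2 `CCOC(=O)CCCCCOc1cccc(CN(C(=O)c2ccc(-c3ccco3)cc2)C(C)C)c1`: compound 2 gives > 26000 nM.
Compound 3 `CCOC(=O)CCCCCOc1cccc(CN(C(=O)c2ccc(-c3cccc(Oc4ccccc4)c3)cc2)C(C)C)c1`: compound 3 gives > 19600 nM.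

Each of these values is a limit of this assay, not a number. Compound 3 sits at the limit of > 19600 nM in this assay, at which 1 of the 3 values shown sits. Compounds 1 and 2 sit at the limit of > 26000 nM in this assay, at which 2 of the 3 values shown sit. Among the measured compounds shown here, the one step between measured compounds, a step that the two limits leave unreadable from compound 1 to compound 2, cannot be read because both ends are limits. Compound 4 `CCOC(=O)CCCCCOc1cccc(CN(C(=O)c2ccc(-c3cccc(OC)c3)cc2)C(C)C)c1` differs from compound 3 by methyl in place of phenyl on an oxygen on an aromatic ring. For the measured compounds named here, no measured step bears on this change, and nothing seen here suggests a readable effect in this assay, so compound 4 is expected to show a step that the limit leaves unreadable from compound 3 to compound 4, most likely ending at a limit again. Compound 4 is therefore estimated at 30000 nM, within 12000 nM to 80000 nM.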

Compound 4, half-maximal effective concentration: > 21000 nM
Compound 4: no number, only a limit; the forecaster's own chance of this, stated with the estimate: 85%; the middle value is on the limit's open side.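

Among the compounds shown here, compound 4 ends at a limit, like compound 1, compound 2 and compound 3, so no step to compound 4 from any of them can be read. The compounds shown leave open whether phenoxy to methoxy changes anything in this assay.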